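Fluorinated Phenyl Tail on a Leukotriene Receptor Antagonist

The source may hold more compounds than are shown below. What is called first, only, known or untested is meant among the compounds shown, and "the series" means these compounds.

Measured compounds:
compound 1 `Cc1c(CCCC(=O)O)c2cccc(/C=C/c3ccc(OCCCCc4ccccc4)cc3)c2n1CC(=O)O`, 4.7 nM
compound 2 `Cc1c(Cl)cccc1CCCCOc1ccc(C#Cc2cccc3c(CCC(=O)O)c(C)n(CCCCC(=O)O)c23)cc1`, 60 nM

In a functional assay on HEK293 cells for antagonist activity at cysteinyl leukotriene receptor 2 (Homo sapiens), read by fluorescence and calcium flux, with stated times of 30 min and 1 h (on this read-out higher numbers stand for weaker inhibition and lower numbers for stronger inhibition), compound 1 gives 4.7 nM, the lowest of the two numbers recorded. Among the measured compounds shown here, the only other measured compound, compound 2, gives 60 nM in this assay, a higher number that lies beyond the usual scatter; no direct step links the two, so their values are simply set side by side.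

Compound 3 `Cc1c(CCCC(=O)O)c2cccc(/C=C/c3ccc(OCCCCc4cc(F)c(F)c(F)c4F)cc3)c2n1CC(=O)O` has not yet been measured. It keeps the core of compound 1 and its chain, and differs in one place: 2,3,4,5-tetrafluorophenyl in place of phenyl on a saturated chain carbon, four bonds along the chain from an oxygen on an aromatic ring

For the measured compounds named here, nothing among the measured compounds shows what such a swap does in this assay, so the expected step from compound 1 to compound 3 is a 1.3-fold higher number from compound 1 to compound 3 (0.11 log units; within the scatter), a small move in either direction that may well sit within the scatter. Compound 3 is accordingly estimated at 6 nM, with a range from 2 nM to 20 nM.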

Compound 3, half-maximal inhibitory concentration in the cysteinyl leukotriene receptor 2 assay: 1.5 nM
Compound 3: the middle estimate sits 4.0-fold (0.60 log units) above what was measured, outside the stated range (below it).
By their numbers in the cysteinyl leukotriene receptor 2 assay, from the lowest: compound 3; then compound 1; then compound 2.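

Setting 2,3,4,5-tetrafluorophenyl in place of phenyl on a saturated chain carbon, four bonds along the chain from an oxygen on an aromatic ring, gives in the cysteinyl leukotriene receptor 2 assay a 3.1-fold lower number from compound 1 to compound 3 (0.50 log units; beyond the scatter), the first sign that the number responds to a change at this position. In a physicochemical assay for permeability, using PAMPA, with a stated time of 4 h, at pH 7.4, tested at 50 uM (on this read-out lower numbers stand for lower permeability and higher numbers for higher permeability), compound 1 gives < 0.05 10^-6 cm/s, which is a limit of the assay and not a number: the limit of < 0.05 10^-6 cm/s in the physicochemical assay, at which 1 of the 2 values shown sits. In the physicochemical assay compound 3 gives 0.3 10^-6 cm/s, and the same change reads as an at least 6.0-fold higher number from compound 1 to compound 3 (0.77 log units; beyond the scatter).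

On these data alone, whether a single fluorine or a trifluoromethyl group on the phenyl would move both numbers in the same way remains open. So does whether the tetrafluorophenyl group would give the same steps at the end of a longer chain.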